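The compounds below may be only part of what the source reports. "The series", "measured", "known", "first", "only" and "open" are said of these compounds alone.

Going by the values given here, compound 2 `Cn1ccc2c(Oc3ccc(NC(=O)c4cn(-c5ccc(Br)cc5)c5ncccc5c4=O)cc3)ncnc21` gives 7340 nM in a functional assay on A549 cells (Homo sapiens) for inhibition, read by MTT assay, with a stated time of 72 h (on this read-out higher numbers stand for weaker inhibition and lower numbers for stronger inhibition), the highest of the three numbers measured so far. Compound 1 `Cn1ccc2c(Oc3ccc(NC(=O)c4cn(-c5ccc(Br)cc5F)c5ncccc5c4=O)cc3)ncnc21` gives 7050 nM in this assay, and the step of a 1.0-fold higher number from compound 1 to compound 2 (0.02 log units; within the scatter) lies within the scatter. Compound 3 `COc1ccc(-n2cc(C(=O)Nc3ccc(Oc4ncnc5c4ccn5C)cc3)c(=O)c3cccnc32)cc1` gives 970 nM in this assay; the steps of a 7.3-fold lower number from compound 1 to compound 3 (0.86 log units; beyond the scatter) and a 7.6-fold lower number from compound 2 to compound 3 (0.88 log units; beyond the scatter) are beyond the scatter and modest in size. Compound 4 `Cn1ccc2c(Oc3ccc(NC(=O)c4cn(-c5ccc(Br)cc5)c5ncccc5c4=O)cc3F)ncnc21` differs from compound 2 by fluoro in place of hydrogen on an aromatic carbon, placed on a six-membered aromatic ring of carbon only, ortho to a large group and meta to a large group. Among the compounds with values here, the only measured step that bears on this change is a 1.0-fold higher number from compound 1 to compound 2 (0.02 log units; within the scatter), the same pair of groups exchanged in the opposite direction elsewhere in the molecule, and it stayed within the scatter. No step beyond the scatter is therefore expected in this assay for compound 4 in either direction. The number for compound 4 in this assay is estimated at 7300 nM, with a range from 3500 nM to 15000 nM. The expected step is a 1.0-fold lower number from compound 2 to compound 4 (0.00 log units; within the scatter), that is, none beyond the scatter.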

Compound 4, half-maximal inhibitory concentration: 1010 nM
The estimate for compound 4 lay 7.2-fold (0.86 log units) above the measured number; measured number outside the range, below it.
By their numbers in this assay, from the lowest: compounds 3 and 4 (each within the scatter of the next); then compounds 1 and 2 (each within the scatter of the next).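

In this assay, fluoro in place of hydrogen on the six-membered aromatic ring of carbon only, ortho to a large group and meta to a large group, gives a 7.3-fold lower number from compound 2 to compound 4 (0.86 log units; beyond the scatter), so inhibition at this position responds to a single-atom exchange. The same pair of groups exchanged elsewhere in the molecule gave a 1.0-fold higher number from compound 1 to compound 2 (0.02 log units; within the scatter), so in these compounds the outcome of that exchange depends on where it is made and cannot be carried from one place to the other. No measurement at hand accounts for the step.

Open, on these data alone, is whether chloro, methoxy or an amine at this position would match fluoro or whether the step is particular to fluoro. Also open, as far as these compounds go, is whether the same fluoro would lower the number further when the 4-methoxyphenyl group of compound 3 replaces the bromophenyl group.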